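Replacing the side group of compound 2

The compounds below may be only part of what the source reports. "The series", "measured", "known", "first", "only" and "open" are said of these compounds alone.

In a functional assay on COR-L23 cells (Homo sapiens) for antiproliferative activity, read by CellTiter-Glo, with a stated time of 72 h (a higher number here means a weaker inhibitor, a lower number a stronger inhibitor), compound 2 (`C[C@@H](c1ccc(NC(=O)N2CC(c3cncc(N)c3)C2)cc1)N1Cc2ccccc2C1=O`) gives 130 nM and has the higher number of the two measured compounds. Compound 1 (`C[C@H](NC(=O)c1cccc(F)c1)c1ccc(NC(=O)N2CC(c3ccc(N)nc3)C2)cc1`) gives 27 nM in this assay and lies beyond the scatter from compound 2. Compound 3 (`C[C@H](NC(=O)c1cccc(F)c1)c1ccc(NC(=O)N2CC(c3cncc(N)c3)C2)cc1`) keeps the rest of compound 2 and changes one group (a group of 10 heavy atoms (7 carbon, 1 nitrogen, 1 oxygen, 1 fluorine; one six-membered aromatic ring of carbon only) in place of a group of 10 heavy atoms (8 carbon, 1 nitrogen, 1 oxygen; one five-membered non-aromatic ring with 1 hetero atom, one six-membered aromatic ring of carbon only), on a saturated chain carbon bound to an aromatic carbon and a saturated chain carbon). The entering ((3-fluorophenyl)carbonyl)amino group is also carried by compound 1, which differs from compound 3 elsewhere in the structure. For the measured compounds named here, no measured pair isolates this change, so the expectation rests on compound 1 at 27 nM alone. A step to a lower number in this assay, beyond the scatter, is expected. The estimated change is a 2.9-fold lower number from compound 2 to compound 3 (0.46 log units; beyond the scatter) and remains uncertain. Compound 3 is estimated at 45 nM (expected range 15 nM to 130 nM).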

Compound 3, half-maximal inhibitory concentration: 630 nM
Estimate against measurement, compound 3: 14-fold (1.15 log units) below, and the stated range ends below it.
By their numbers in this assay, from the lowest: compound 1; then compound 2; then compound 3.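

In this assay, the ((3-fluorophenyl)carbonyl)amino group does not lower the number when it enters on the saturated chain carbon with 5-aminopyridin-3-yl held fixed: the change gives a 4.8-fold higher number from compound 2 to compound 3 (0.69 log units; beyond the scatter) and runs against the direction suggested by compound 1 alone. With the ((3-fluorophenyl)carbonyl)amino group held fixed, 5-aminopyridin-3-yl in place of 6-aminopyridin-3-yl on the saturated ring carbon gives a 23-fold higher number from compound 1 to compound 3 (1.37 log units; beyond the scatter) and shows that the side group's effect cannot be read apart from this ring substituent. No available evidence gives a cause for either step.

Still open, going by these compounds, is how the group that leaves compound 2 behaves with 6-aminopyridin-3-yl, which would show whether the two changes act independently. Also open, on these data alone, is how an unsubstituted benzoylamino group would read on the saturated chain carbon.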